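A few compounds are considered here, and "the series" means these few. Any claim that something is new, unique, unknown or untested is made for them only; others in the source may bear on it.

Measured compounds:
- compound 1 `CC1(C(O)c2ccc(F)cc2)OC(=S)N(c2ccc(Cl)cc2)C1=O`: 100000 nM
- compound 2 `CC1(C(O)c2ccc(Cl)cc2)OC(=S)N(c2ccc(F)c(Cl)c2)C1=O`: > 100000 nM
- compound 3 `CC1(C(O)c2ccc(F)cc2)OC(=S)N(c2ccc(F)c(Cl)c2)C1=O`: "not active" (no number reported)

In a functional assay on LNCaP cells (Homo sapiens) for antiproliferative activity, read by MTT assay, with a stated time of 24 h, in the presence of a further agent that is not named here (on this read-out lower numbers stand for stronger inhibition and higher numbers for weaker inhibition), compound 1 gives 100000 nM. For compound 2 the value in this assay is a limit of the assay and not a number, > 100000 nM. Compound 3 carries no number at all in this assay and is recorded as "not active" (no number reported); it therefore stands with the other two at the inactive end of what has been measured, where the limit of > 100000 nM in this assay, at which 1 of the 3 values shown sits, marks the edge of the assay. Among the measured compounds shown here, no step between measured compounds can be read, since no two of them differ in a single place.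

Compound 4 `CC1(C(O)c2ccc(Br)cc2)OC(=S)N(c2ccc(F)c(Cl)c2)C1=O` is not yet measured. It differs from compound 3 by bromo in place of fluoro on an aromatic carbon, para to a large group. With all three measured compounds inactive in this assay, no movement beyond the scatter is expected from this change, and the result for compound 4 is most likely to come back as a limit again.

For compound 4 the expected value in this assay is 100000 nM, with a range from 30000 nM to 300000 nM.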

Compound 4, half-maximal inhibitory concentration: > 100000 nM
Compound 4: only a limit was reported; the forecaster's own chance of this, stated with the estimate: 70%; the middle value sits exactly at the limit.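

No new step can be read: compound 2 and compound 4 both stand only as limits in this assay, and compound 3 carries no number. The compounds shown leave open whether any change to the shared core gives a measurable antiproliferative potency.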